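From an ether chain to a bromophenyl group at the carbonyl

The compounds below may be only part of what the source reports. "The series", "measured", "known", "first", "only" and "open" are said of these compounds alone.

This account follows a single change on a shared core and what it does in an ADME assay on Vero cells (Chlorocebus sabaeus) for cytotoxicity, read by resazurin assay, with a stated time of 3 days; a higher number here means a weaker inhibitor, a lower number a stronger inhibitor. Compound 1 `C=Cc1cccc(C(=O)Nc2cc3nc(C4CCCCC4)[nH]c3cc2N(CC)CC)c1` carries a 3-vinylphenyl group on its carbonyl carbon. In this assay compound 1 reaches only the limit of > 100 ug/mL, which is not a number. Compound 2 `CCN(CC)c1cc2[nH]c(C3CCCCC3)nc2cc1NC(=O)OCCOCCOC` carries 2-(2-methoxyethoxy)ethoxy at that carbonyl carbon instead. In this assay compound 2 also stops at the limit of > 100 ug/mL, again not a number. The step that the two limits leave unreadable from compound 1 to compound 2 therefore cannot be sized, since both readings sit at the limit of > 100 ug/mL in this assay, at which 2 of the 2 values shown sit.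

Compound 3 `CCN(CC)c1cc2[nH]c(C3CCCCC3)nc2cc1NC(=O)c1ccc(Br)cc1` differs from compound 2 by 4-bromophenyl in place of 2-(2-methoxyethoxy)ethoxy on a carbonyl carbon. Among the measured compounds shown here, the only measured step, from compound 1 to compound 2, touches the same carbonyl carbon but is unreadable, so no size or direction can be taken from it. Compound 3 is expected to give 100 ug/mL, within 40 ug/mL to 200 ug/mL. The step of a number no higher from compound 2 to compound 3 (the limit leaves the size open) is thus estimated as nothing beyond the scatter. This expectation rests on compound 1, whose 3-vinylphenyl group on the same carbonyl carbon gave > 100 ug/mL, a limit.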

Compound 3, half-maximal inhibitory concentration: > 100 ug/mL
Compound 3: a limit, no number; the forecaster's own chance of this, stated with the estimate: 70%; the middle value lies on the limit itself.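

In this assay compound 3 gives > 100 ug/mL as a limit and not a number. Among the compounds shown here, no step among compound 1, compound 2 and compound 3 can therefore be read, since all three readings stop at the same limit: the limit of > 100 ug/mL in this assay, at which 3 of the 3 values shown sit. In this assay the compounds shown leave open what a change on the carbonyl carbon does to a reading that is a number.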